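The compounds below may be only part of what the source reports. "The series", "measured", "known", "first", "only" and "open" are said of these compounds alone.

Compound 1 `CCn1cc(COc2cc(O)c3c(c2)O[C@H](c2ccc(OC)c(O)c2)CC3=O)nn1`: 15000 nM in a functional assay on RAW264.7 cells (Mus musculus) for inhibition, read by Griess assay, with stated times of 2 h and 24 h; on this read-out lower numbers stand for stronger inhibition and higher numbers for weaker inhibition
Compound 2 `COc1ccc([C@@H]2CC(=O)c3c(O)cc(OCc4cn(Cc5cccc(C#N)c5)nn4)cc3O2)cc1O`: 18000 nM in this assay
Compound 3 `COc1ccc([C@@H]2CC(=O)c3c(O)cc(OCc4cn(C5CCC5)nn4)cc3O2)cc1O`: 15300 nM in this assay

The three measured compounds share one core and differ only in the group carried on the aromatic nitrogen. Compound 1 stands within the scatter of both companions: the step of a 1.0-fold higher number from compound 1 to compound 3 (0.01 log units; within the scatter) and the step of a 1.2-fold higher number from compound 1 to compound 2 (0.08 log units; within the scatter) are both within the scatter, as is the step of a 1.2-fold lower number from compound 2 to compound 3 (0.07 log units; within the scatter). Nothing among these three separates an ethyl, a cyclobutyl or a 3-cyanobenzyl on that nitrogen.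

Compound 4 `CCCn1cc(COc2cc(O)c3c(c2)O[C@H](c2ccc(OC)c(O)c2)CC3=O)nn1` is not yet measured. It differs from compound 1 by methyl in place of hydrogen on a saturated chain carbon, two bonds along the chain from an aromatic nitrogen. Every measured step alters the same group on the aromatic nitrogen, and each of them bears on this change. Each stayed within the scatter, including the larger swap to 3-cyanobenzyl. A change from ethyl to propyl is smaller than any of those, so no movement beyond the scatter is expected in this assay, and the expected step is no change at the digits printed from compound 1 to compound 4 (within the scatter). Compound 4 is therefore estimated at 15000 nM, with a range from 7500 nM to 30000 nM.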

Compound 4, half-maximal inhibitory concentration: 9670 nM
Compound 4: the middle estimate sits 1.6-fold (0.19 log units) above what was measured; measured number inside the range.
By their numbers in this assay, from the lowest: compounds 4, 1, 3 and 2 (each within the scatter of the next).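

The added methyl on a saturated chain carbon, two bonds along the chain from an aromatic nitrogen, turns ethyl into propyl and gives a 1.6-fold lower number from compound 1 to compound 4 (0.19 log units; within the scatter) in this assay, so this first straight-chain extension at the position does not separate the two compounds. The comparisons with the ring-bearing groups read the same way, with a 1.6-fold lower number from compound 3 to compound 4 (0.20 log units; within the scatter) against cyclobutyl and a 1.9-fold lower number from compound 2 to compound 4 (0.27 log units; within the scatter) against 3-cyanobenzyl, so all four groups on the aromatic nitrogen, open-chain or ring-bearing, remain unseparated in this read-out. No supporting measurement bears on why the numbers fall as they do.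

On these data alone, whether a butyl or longer chain, an amine or a carboxylic acid on the aromatic nitrogen would give a step beyond the scatter remains open. Equally open, as far as these compounds go, is whether a change elsewhere on the shared core would move the number in a way that these changes on the aromatic nitrogen do not.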